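Thiazolidinone amides: triazole-to-imide swap on the butyl chain

The source may report more compounds than this note shows. Statements on the series, on what has been measured and on what is new or still open speak of the compounds shown alone.

Compound 1 `COc1ccccc1N1C(=O)CSC1c1cccc(C(=O)NCCCCn2cncn2)c1` carries the shared core with a methoxyphenyl on the ring nitrogen and a triazole at the far end of the chain. In a functional assay on HOS-TE85 cells (Homo sapiens) for inhibition, read by CCK-8 assay, with a stated time of 72 h (a higher number here means a weaker inhibitor, a lower number a stronger inhibitor), compound 1 gives only a limit, > 1000 nM, and no number. It therefore sits at the limit of > 1000 nM in this assay, at which 1 of the 2 values shown sits. Compound 2 `O=C(NCCCCc1ccccc1)c1cccc(C2SCC(=O)N2c2ccccn2)c1`, a pyridyl analogue with a phenyl at the chain end, is the other measured member; in this assay compound 2 gives 19.7 nM. For the measured compounds named here, no step between these two is computed here, so the two values are taken simply as they stand.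

Compound 3 `COc1ccccc1N1C(=O)CSC1c1cccc(C(=O)NCCCCN2C(=O)C=CC2=O)c1` is the unmeasured follow-on to compound 1. The change is a group of 7 heavy atoms (4 carbon, 1 nitrogen, 2 oxygen; one five-membered non-aromatic ring with 1 hetero atom) in place of a group of 5 heavy atoms (2 carbon, 3 nitrogen; one five-membered aromatic ring with 3 hetero atoms), on a saturated chain carbon, four bonds along the chain from an amide-type nitrogen. Because compound 1 stands at the limit of > 1000 nM in this assay, at which 1 of the 2 values shown sits, the starting point is itself only a limit, so the direction of the step cannot be read from a measured pair. The expectation is that compound 3 stays weak, with a step that the limit leaves unreadable from compound 1 to compound 3 expected to be no more than the usual scatter around the limit. Compound 3 is estimated at 2000 nM in this assay, within 300 nM to 10000 nM.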

Compound 3, half-maximal inhibitory concentration: > 1000 nM
Compound 3 gave a limit, no number; the forecaster's own chance of this, stated with the estimate: 60%; the middle value lies beyond the limit too.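

In this assay no step can be read from compound 1 to compound 3, because each of the two gives only a limit and no number: the limit of > 1000 nM in this assay, at which 2 of the 3 values shown sit. From the compounds shown here alone, it remains open whether replacing the 1H-1,2,4-triazol-1-yl group of compound 1 with the group in compound 3 shifts inhibition at all, and what number either compound would give.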